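This account rests on a few compounds, and the source may have more. Where it says the series, first, only, none or still open, it means among the compounds named here.

Compound 1, `Nc1cc(N)c2nc(-c3ccccc3)c(Oc3ccc(Cl)c(Cl)c3)nc2c1`, is the starting point. For the measured compounds named here, in a functional assay on MCF7 cells (Homo sapiens) for inhibition, read by sulforhodamine B assay, with a stated time of 48 h (a lower number here means a stronger inhibitor of growth, a higher number a weaker inhibitor of growth), compound 1 gives 70800 nM, and this is the only plain number in the set. Compound 2, `COc1ccc(CNc2nc3cc(N)cc(N)c3nc2-c2ccccc2)cc1OC`, reaches only a limit of the assay: in this assay compound 2 gives < 100000 nM. Compound 3, `CCOC(=O)[C@H](CCC(=O)O)NC(=O)c1ccc(Sc2nc3cc(N)cc(N)c3nc2-c2ccccc2)cc1`, likewise stops at a limit: in this assay compound 3 gives < 100000 nM. Going by the values given here, compound 1 therefore stands alone as the one measured number, with nothing to rank it against. The unmeasured compound 4 is `COc1ccc(Sc2nc3cc(N)cc(N)c3nc2-c2ccccc2)cc1`. It differs from compound 1 in one place: (4-methoxyphenyl)sulfanyl in place of 3,4-dichlorophenoxy on an aromatic carbon. Among the compounds with values here, no step between measured compounds is available to size this change, so the expectation rests on compound 1 alone. A step of no clear direction beyond the usual scatter is expected, a 1.2-fold lower number from compound 1 to compound 4 (0.07 log units; within the scatter). A limit rather than a number is a real possibility because of the limit of < 100000 nM in this assay, at which 2 of the 3 values shown sit. Compound 4 is estimated at 60000 nM in this assay, within a range from 15000 nM to 200000 nM.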

Compound 4, concentration for total growth inhibition: < 100000 nM
Compound 4 was reported as a limit; the forecaster's own chance of this, stated with the estimate: 40%; the middle value lies beyond the limit too.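

In this assay, for the compounds shown here, compound 4 gives < 100000 nM, which is a limit of the assay and not a number, so no step from compound 1 to compound 4 can be read. The compounds shown leave open whether (4-methoxyphenyl)sulfanyl in place of 3,4-dichlorophenoxy changes growth inhibition at all.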